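A few compounds are considered here, and "the series" means these few. Any claim that something is new, unique, unknown or untested is made for them only; others in the source may bear on it.

Series notes. The shared core appears in compound 1, `O=C1NCCc2nc(C#Cc3ccccc3)sc21`, and in compound 2, `C(#Cc1nc2c(s1)CN(C1CCCCC1)CC2)c1ccccc1`. In an assay on HEK293 cells for positive allosteric modulation of metabotropic glutamate receptor 5 (Homo sapiens), read by FLIPR, with a stated time of 1 h (on this read-out lower numbers stand for an effect already at smaller amounts and higher numbers for an effect only at larger amounts of compound), compound 1 gives 112 nM. In this assay compound 2 gives only > 10000 nM, which is a limit of the assay and not a number; (the limit of > 10000 nM in this assay, at which 1 of the 2 values shown sits). Within the data shown here, compound 2 therefore stands at the edge of what the assay reports, and no step between two measured compounds is available for comparison.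

Compound 3, `COC1CC(C(=O)N2CCc3nc(C#Cc4ccccc4)sc3C2)C1`, awaits measurement. It differs from compound 2 in one place: (3-methoxycyclobutyl)carbonyl in place of cyclohexyl on an amine nitrogen in a ring. The step in this assay is expected to run toward lower numbers and to be well beyond the usual scatter, the main point of reference being compound 1, which gives 112 nM. Compound 3 is estimated at 300 nM, with a range from 60 nM to 2000 nM. This corresponds to an expected step of an at least 33-fold lower number from compound 2 to compound 3 (1.52 log units; beyond the scatter).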

Compound 3, half-maximal effective concentration: 640 nM
For compound 3 the middle estimate is 2.1-fold (0.33 log units) below the measured one, within the range that was stated.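

On the amine nitrogen in a ring, the group carried there now decides whether the compound gives a readable value: with (3-methoxycyclobutyl)carbonyl in place of cyclohexyl, the series shows an at least 15-fold lower number from compound 2 to compound 3 (1.19 log units; beyond the scatter). Among these compounds, this is the first step available, and it shows that this position responds strongly to the change. In this assay compound 2 gives > 10000 nM, which is a limit of the assay and not a number, so the step is a bound and its full size cannot be read: the limit of > 10000 nM in this assay, at which 1 of the 3 values shown sits.

The change alters several things at once: the ring size, the carbonyl and the methoxy group, and the compounds shown do not separate their shares in the step. On these data alone, whether a cyclohexylcarbonyl or an unsubstituted cyclobutylcarbonyl on the same nitrogen would give a similar value remains open.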